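The compounds below may be only part of what the source reports. "The series", "measured", "known", "first", "only" and "open" are said of these compounds alone.

In a functional assay on A549 cells (Homo sapiens) for cytotoxicity, read by MTT assay, with a stated time of 72 h (on this read-out higher numbers stand for weaker inhibition and lower numbers for stronger inhibition), compound 1 (`CCC[S+]([O-])CCCCN=C=S`) gives 10700 nM. Compound 2 (`CC(C)C[S+]([O-])CCCCN=C=S`) gives 9090 nM, and these two values lie within the scatter of each other, so neither can be ranked above the other. Compound 3 (`[O-][S+](CCCCN=C=S)Cc1cccs1`) has not yet been measured. It differs from compound 2 as follows: thiophen-2-yl in place of isopropyl on a saturated chain carbon bound to a sulfur. Going by the values given here, only one measured step offers any guide: a 1.2-fold lower number from compound 1 to compound 2 (0.07 log units; within the scatter). That step added only a methyl in place of hydrogen on a saturated chain carbon, and neither measured compound carries a ring, so it bears on the new change only loosely. With so little evidence, no step beyond the scatter is expected in this assay. The estimated step is a 1.1-fold lower number from compound 2 to compound 3 (0.06 log units; within the scatter). For compound 3 the expected value is 8000 nM, within an estimated range of 3500 nM to 18000 nM.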

Compound 3, half-maximal inhibitory concentration: 8410 nM
Compound 3: middle estimate off by 1.1-fold (0.02 log units), on the low side, and the stated range covers the measured number.
By their numbers in this assay, from the lowest: compounds 3, 2 and 1 (each within the scatter of the next).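

In this assay, going by these compounds alone, the saturated chain carbon bound to a sulfur carries a ring for the first time: thiophen-2-yl, a five-membered aromatic ring with 1 hetero atom, replaces isopropyl and gives a 1.1-fold lower number from compound 2 to compound 3 (0.03 log units; within the scatter). Measured against ethyl, thiophen-2-yl gives a 1.3-fold lower number from compound 1 to compound 3 (0.10 log units; within the scatter), so at this place a change from an open chain to this aromatic ring, with its one hydrogen-bond acceptor, brings no step beyond the scatter. No measured property of these groups is available to account for this result.

As far as these compounds go, whether an amine, a carboxylic acid or a longer chain at this place would bring a step beyond the scatter stays open. What a change elsewhere in the shared core would do is open as well.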